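Sulfonamide nitrogen substituents in the shared core series

The source may hold more compounds than are shown below. What is called first, only, known or untested is meant among the compounds shown, and "the series" means these compounds.

Measured compounds:
compound 1 `CNS(=O)(=O)c1ccc2c(c1)C(n1ccccc1=O)=CC(C)(C)O2`: 85.8%
compound 2 `CCNS(=O)(=O)c1ccc2c(c1)C(n1ccccc1=O)=CC(C)(C)O2`: 72.4%

In a functional assay on the whole organism (aorta) with Rattus norvegicus as the target (on this read-out lower numbers stand for smaller maximal responses and higher numbers for larger maximal responses), compound 2 gives 72.4%, the lowest of the two numbers; compound 1 sits higher by a number 13.4 percentage points lower from compound 1 to compound 2 (beyond the scatter). Compound 3 `COc1ccc(NS(=O)(=O)c2ccc3c(c2)C(n2ccccc2=O)=CC(C)(C)O3)cc1` is not yet measured. Relative to compound 2 the change is 4-methoxyphenyl in place of ethyl on a sulfonamide nitrogen. Among the compounds with values here, the only step that bears on this position is a number 13.4 percentage points lower from compound 1 to compound 2 (beyond the scatter), a modest drop on growing the sulfonamide nitrogen substituent by one carbon. Within the data shown here, the present change is larger and brings in a ring and an acceptor, for which no comparison exists; the sole step points downward, so a further decrease in this assay is expected, with wide uncertainty. Compound 3 is therefore estimated at 60%, range 40% to 80%, a step of a number 12.4 percentage points lower from compound 2 to compound 3 (beyond the scatter) expected from compound 2.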

Compound 3, largest response reached (Emax), in percent of the reference or control that the assay uses: 77.9%
Estimate against measurement, compound 3: 17.9 percentage points below; measured number inside the range.
By their numbers in this assay, from the lowest: compounds 2, 3 and 1 (each within the scatter of the next, the first and the last beyond it).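

Placing 4-methoxyphenyl on the sulfonamide nitrogen in place of ethyl gives, in this assay, a number 5.5 percentage points higher from compound 2 to compound 3 (within the scatter), and placing it there in place of methyl gives a number 7.9 percentage points lower from compound 1 to compound 3 (within the scatter). This nitrogen therefore carries a six-membered aromatic ring with a value within the scatter of both alkyl compounds, and compound 3 goes against any reading of the earlier methyl-to-ethyl step as a steady trend with growing substituent. No measurement at hand accounts for these numbers.

Open, as far as these compounds go, is whether the methoxy group contributes anything, which a plain phenyl, a benzyl group or a 4-chlorophenyl on the same nitrogen would help to settle. Also open, from the compounds shown here alone, is how a longer chain such as n-butyl, an aminoethyl chain or a carboxylic acid-bearing chain would read out at this position.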